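The source may report more compounds than this note shows. Statements on the series, on what has been measured and on what is new or still open speak of the compounds shown alone.

Measured so far:
compound 1, `CCCCCCCCCCOc1ccc(-c2coc3cc(OCCCCCCCCCC)cc(O)c3c2=O)cc1`, in a functional assay on HL-60 cells (Homo sapiens) for inhibition, read by MTT assay (a higher number here means a weaker inhibitor of growth, a lower number a stronger inhibitor of growth), gives 3.09 uM
compound 2, `O=c1c(-c2ccc(O)cc2)coc2cc(OC(F)F)cc(O)c12`, in this assay gives 3.53 uM
compound 3, `CC(=O)Oc1ccc(-c2coc3cc(OC(C)=O)cc(O)c3c2=O)cc1`, in this assay gives 5.86 uM

Compound 3 has the highest of the three numbers, but neither neighbour is far away: compound 2 sits within the scatter of it, and compound 1 does too, so the three compounds cannot be told apart on these numbers. Compound 4, `CC(=O)Oc1cc(O)c2c(=O)c(-c3ccc(O)cc3)coc2c1`, has not yet been measured. It differs from compound 3 in one place: hydrogen in place of acetyl on an oxygen on an aromatic ring. The acetyl on the other oxygen of compound 3 is kept.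

For the measured compounds named here, no measured pair shows this change directly. Compound 2, which carries a free hydroxy on the same phenyl ring, gives a number close to that of compound 3, so the three numbers leave no room for a firm expectation of a large move. The step is therefore expected to be small, if anything toward a lower number, and most likely not beyond the scatter. Compound 4 is expected to give 4.5 uM in this assay, within a range of 2 uM to 10 uM. The expected step of a 1.3-fold lower number from compound 3 to compound 4 (0.11 log units; within the scatter) is an estimate only.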

Compound 4, concentration for growth inhibition (reported as GI): 4.95 uM
For compound 4 the middle estimate is 1.1-fold (0.04 log units) below the measured one; the measured number falls inside the stated range.
By their numbers in this assay, from the lowest: compounds 1, 2, 4 and 3 (each within the scatter of the next).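

For the compounds shown here, compound 4 gives the first direct reading of acetoxy to hydroxy on an oxygen on an aromatic ring. In this assay, this change is a 1.2-fold lower number from compound 3 to compound 4 (0.07 log units; within the scatter), so with the other acetyl kept, the acetyl on this oxygen can give way to hydrogen without a change that can be told from the scatter. The same compound also gives a reading at the other oxygen: with the free hydroxy held in place, acetyl in place of difluoromethyl is a 1.4-fold higher number from compound 2 to compound 4 (0.15 log units; within the scatter), so these two groups cannot be told apart there in this assay either. No supporting measurement is available to explain why these numbers stay so close.

Going by these compounds, both readings cover only a narrow set of groups and come from single pairs, so it remains open whether an amine or a carboxylic acid on either oxygen would move the number beyond the scatter. On these data alone, it is also open whether hydrogen in place of the remaining acetyl, leaving a hydroxy on both oxygens, would keep the number in the same range.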